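Compound 3 in the melanin-concentrating hormone receptor 1 series

The source may hold more compounds than are shown below. What is called first, only, known or untested is meant among the compounds shown, and "the series" means these compounds.

Measured so far:
compound 1, `O=C(COc1cccc(Cl)c1)NC1CCN(Cc2ccn(-c3ccccc3)c2)CC1`, 710 nM
compound 2, `COc1ccc(-n2ccc(CN3CCC(NC(=O)COc4cccc(Cl)c4)CC3)c2)cc1`, 100 nM

Both were tested in an assay on HEK293 cells for displacement of a labelled ligand from melanin-concentrating hormone receptor 1 (Homo sapiens); on this read-out higher numbers stand for weaker inhibition and lower numbers for stronger inhibition. Within the data shown here, compound 2 holds the lowest of the two numbers; its only neighbour is compound 1, and the step of a 7.1-fold lower number from compound 1 to compound 2 (0.85 log units; beyond the scatter), methoxy in place of hydrogen on an aromatic carbon, lies beyond the scatter.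

Compound 3, `N#Cc1ccc(-n2ccc(CN3CCC(NC(=O)COc4cccc(Cl)c4)CC3)c2)cc1`, is not yet measured. It differs from compound 2 by cyano in place of methoxy on an aromatic carbon, para to a large group. Among the measured compounds shown here, only the step from compound 1 to compound 2 bears on this change, and it shows that a group at this position, rather than hydrogen, gave the lower number. Nothing measured separates methoxy from cyano there.

Compound 3 is therefore expected to sit close to compound 2, with the step of a 1.5-fold higher number from compound 2 to compound 3 (0.18 log units; within the scatter) estimated as small and likely within the scatter. The estimate for compound 3 is 150 nM, ranging from 40 nM to 600 nM.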

Compound 3, half-maximal inhibitory concentration: 52 nM
For compound 3 the middle estimate is 2.9-fold (0.46 log units) above the measured one; the measured number falls inside the stated range.
By their numbers in this assay, from the lowest: compounds 3 and 2 (each within the scatter of the next); then compound 1.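

In this assay the exchange of methoxy for cyano gives a 1.9-fold lower number from compound 2 to compound 3 (0.28 log units; within the scatter) and so does not separate the two groups at this place on the ring. Set against hydrogen, cyano gives a 14-fold lower number from compound 1 to compound 3 (1.14 log units; beyond the scatter) and this shows that the lower number seen with methoxy is not confined to methoxy: two different groups, para to a large group, both stand beyond the scatter from compound 1. No measurement shown accounts for this shared result.

On these data alone, whether the same holds for a methyl group, a chlorine atom, an amine or a carboxylic acid at this place remains open. Also open, as far as these compounds go, is whether cyano or methoxy on another carbon of the same aromatic ring would give a similar number.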